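A few compounds are considered here, and "the series" means these few. Any claim that something is new, unique, unknown or untested is made for them only; others in the source may bear on it.

In a functional assay on KB cells (Homo sapiens) for antiproliferative activity, read by colorimetric assay and MTT assay (a lower number here means a stronger inhibitor, a higher number a weaker inhibitor), compound 1 `COc1ccc(S(=O)(=O)Nc2cccc3cc[nH]c23)cc1` gives 0.67 ug/mL and stands at the upper end of the numbers. It is level within the scatter with compound 2 `COc1ccc(S(=O)(=O)Nc2ccc(Cl)c3cc[nH]c23)cc1` at 0.92 ug/mL and lies clearly higher than compound 3 `COc1ccc(S(=O)(=O)Nc2cccc3cc(O)[nH]c23)cc1` at 0.1 ug/mL in this comparison.

Compound 4 `Nc1ccc(S(=O)(=O)Nc2cccc3cc[nH]c23)cc1` keeps the core of compound 1 and differs by a single change (amino in place of methoxy on an aromatic carbon) that puts amino in place of methoxy, para to a large group. Neither measured step touches the methoxy, so both bear on it only indirectly. Chloro in place of hydrogen gave a 1.4-fold higher number from compound 1 to compound 2 (0.14 log units; within the scatter) and hydroxy in place of hydrogen gave a 6.7-fold lower number from compound 1 to compound 3 (0.83 log units; beyond the scatter) on the shared core. Among the compounds with values here, they show only that one change can stay within the scatter or go modestly beyond it.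

With no measured change at this place, no step beyond the scatter is expected in this assay and only a slight lean towards a higher number. The expected change is a 1.5-fold higher number from compound 1 to compound 4 (0.17 log units; within the scatter) as an estimate. For compound 4 the estimated value is 1 ug/mL with an expected range from 0.3 ug/mL to 3.5 ug/mL in repeated measurements.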

Compound 4, half-maximal inhibitory concentration: 36 ug/mL
For compound 4 the middle estimate is 36-fold (1.56 log units) below the measured one; the measured number lies above the stated range.
By their numbers in this assay, from the lowest: compound 3; then compounds 1 and 2 (each within the scatter of the next); then compound 4.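

Within the data shown here, on the shared core, the methoxy position proves far more sensitive than the earlier compounds could indicate: in this assay, amino in place of methoxy, para to a large group, gives a 54-fold higher number from compound 1 to compound 4 (1.73 log units; beyond the scatter) and is the first step here to be graded large. This single exchange moves the number further than the modest step of a 6.7-fold lower number from compound 1 to compound 3 (0.83 log units; beyond the scatter) and in the opposite direction, so changes to this core can shift activity either way. Nothing available accounts for the size of this step.

The compounds shown leave open whether the loss belongs to amino itself or would follow any replacement of methoxy at this place. An ethoxy or a dimethylamino group there, on the same core, would help separate those two readings.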